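Bicyclic amide replacements on a guanidine-bearing core

A few compounds are considered here, and "the series" means these few. Any claim that something is new, unique, unknown or untested is made for them only; others in the source may bear on it.

Measured in a functional assay on HEK293 cells for antagonist activity at melanin-concentrating hormone receptor 1 (Homo sapiens); on this read-out higher numbers stand for weaker inhibition and lower numbers for stronger inhibition:
compound 1, `N=C(N)NCCC[C@@H](NC(=O)c1ccc2ccccc2c1)C(=O)NCc1ccc(C(F)(F)F)cc1`: 212 nM
compound 2, `N=C(N)NCCC[C@@H](NC(=O)c1ccnc2ccccc12)C(=O)NCc1ccc(C(F)(F)F)cc1`: 1030 nM
compound 3, `N=C(N)NCCC[C@@H](NC(=O)c1ccc2ccccc2n1)C(=O)NCc1ccc(C(F)(F)F)cc1`: 904 nM

Compound 2 gives the highest number of the three in this assay. Its nearest neighbour is compound 3, with a 1.1-fold lower number from compound 2 to compound 3 (0.06 log units; within the scatter), so the two are not separable. Compound 1 stands furthest away, with a 4.9-fold higher number from compound 1 to compound 2 (0.69 log units; beyond the scatter).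

The next compound, compound 4, `N=C(N)NCCC[C@@H](NC(=O)c1cc2ccccc2cn1)C(=O)NCc1ccc(C(F)(F)F)cc1`, differs from compound 2 in one place: isoquinolin-3-yl in place of quinolin-4-yl on a carbonyl carbon.

Both steps that start from compound 1 bear on this change, since each swaps one bicyclic amide substituent for another: a 4.9-fold higher number from compound 1 to compound 2 (0.69 log units; beyond the scatter) and a 4.3-fold higher number from compound 1 to compound 3 (0.63 log units; beyond the scatter). The step between the two nitrogen-bearing bicycles, a 1.1-fold lower number from compound 2 to compound 3 (0.06 log units; within the scatter), lies within the scatter. Moving the nitrogen to a third position, as here, has no direct precedent among the measured compounds, but the two measured nitrogen-bearing bicycles gave closely matched numbers in this assay. A step from compound 2 to compound 4 of no more than the scatter is therefore expected, with a slight lean towards a lower number. The estimate for compound 4 is 800 nM, ranging from 300 nM to 2500 nM, which means an expected 1.3-fold lower number from compound 2 to compound 4 (0.11 log units; within the scatter).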

Compound 4, half-maximal inhibitory concentration: 1810 nM
The estimate for compound 4 lay 2.3-fold (0.35 log units) below the measured number, and the stated range covers the measured number.
By their numbers in this assay, from the lowest: compound 1; then compounds 3, 2 and 4 (each within the scatter of the next).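

In this assay the new data give a 1.8-fold higher number from compound 2 to compound 4 (0.24 log units; within the scatter) and a 2.0-fold higher number from compound 3 to compound 4 (0.30 log units; within the scatter), both within the scatter, so isoquinolin-3-yl on the carbonyl carbon cannot be separated from quinolin-4-yl or quinolin-2-yl, and moving the ring nitrogen among these three groups does not resolve them on this read-out. The contrast with naphthalen-2-yl extends to this third nitrogen-bearing bicycle, with an 8.5-fold higher number from compound 1 to compound 4 (0.93 log units; beyond the scatter) beyond the scatter, so all three such groups give a higher number than compound 1, and no compound shown goes against this. Nothing shown gives a reason for that contrast.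

On these data alone, it remains open whether the gap to compound 1 is specific to a ring nitrogen, or whether it would also appear with an amine or a methoxy group carried on naphthalen-2-yl. Also open, as far as these compounds go, is whether the same contrast between these bicycles holds with a carboxylic acid in place of the guanidine, or with a nitrile in place of the trifluoromethyl group.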